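The source may hold more compounds than are shown below. What is called first, only, known or untested is meant among the compounds shown, and "the series" means these compounds.

Compound 1 `O=C1/C(=C/c2ccccc2F)CN(Cc2cn(Cc3ccc(F)cc3)nn2)C/C1=C\c1ccccc1F` and compound 3 `Cc1ccc(/C=C2\CN(Cc3cn(Cc4ccc(F)cc4)nn3)C/C(=C\c3ccc(C)cc3)C2=O)cc1` share a core that compound 2 `Cc1ccc(/C=C2\CN(C(=S)SCc3cn(Cc4ccccc4Cl)nn3)C/C(=C\c3ccc(C)cc3)C2=O)cc1` and compound 4 `Cc1ccc(/C=C2\CN(C(=S)SCc3cn(Cc4ccc(F)cc4)nn3)C/C(=C\c3ccc(C)cc3)C2=O)cc1` carry as well. In a functional assay on MCF7 cells (Homo sapiens) for cytotoxicity, read by MTT assay, with a stated time of 24 h (a lower number here means a stronger inhibitor, a higher number a weaker inhibitor), compound 1 gives 6000 nM, and compound 3 gives 29000 nM. Compound 2 reaches only a limit of the assay, > 100000 nM, so no number is known for it, and among the three values shown it stands at the limit of > 100000 nM in this assay, at which 1 of the 3 values shown sits. The change from compound 2 to compound 4 is 4-fluorophenyl in place of 2-chlorophenyl on a saturated chain carbon bound to an aromatic nitrogen. Going by the values given here, no step between measured compounds matches this change, and a limit offers no base from which a direction in this assay can be read. Compound 4 is therefore expected to stay near the limit, the step of a number no higher from compound 2 to compound 4 (the limit leaves the size open) taken as none beyond the scatter. For compound 4 the estimate in this assay is 100000 nM, in a range from 30000 nM to 400000 nM.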

Compound 4, half-maximal inhibitory concentration: 81600 nM
The estimate for compound 4 lay 1.2-fold (0.09 log units) above the measured number; the range from low to high includes it.
By their numbers in this assay, from the lowest: compound 1; then compound 3; then compound 4. At a limit, above all of these: compound 2.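

In this assay compound 2 is a limit of the assay, not a number: the limit of > 100000 nM in this assay, at which 1 of the 4 values shown sits. Compound 4, with 4-fluorobenzyl in place of 2-chlorobenzyl, gives this position a measured value, and the change reads as an at least 1.2-fold lower number from compound 2 to compound 4 (0.08 log units; that floor lies within the scatter). Going by these compounds, the true size of that step stays unknown, so the compounds show only its floor.

The compounds shown leave open how this position responds to other groups, such as 4-aminobenzyl or 4-carboxybenzyl. They also leave open whether a longer chain at this place would change the number.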